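The source may report more compounds than this note shows. Statements on the series, on what has been measured and on what is new or still open speak of the compounds shown alone.

- Compound 1 `Oc1ccc2cc1Oc1ccc(cc1)CCc1cc(O)c(c(O)c1)Oc1cccc(c1)CC2`: 29900 nM
- Compound 2 `Oc1ccc2cc1Oc1ccc(cc1)CCc1ccc(O)c(c1)Oc1ccc(cc1)CC2`: 10300 nM

In a functional assay on K562 cells (Homo sapiens) for antiproliferative activity, read by MTT assay, with a stated time of 48 h (on this read-out higher numbers stand for weaker inhibition and lower numbers for stronger inhibition), compound 2 has the lower of the two numbers, and its gap to compound 1 lies beyond the usual scatter. Compound 3 `Oc1ccc2cc1Oc1ccc(cc1)CCc1ccc(O)c(c1)Oc1ccc(cc1O)CC2` differs from compound 2 by one change, hydroxy in place of hydrogen on an aromatic carbon. Within the data shown here, no measured pair shows this change alone, so the expectation is uncertain: a small move toward stronger inhibition, possibly no more than the scatter. The expected change is a 1.4-fold lower number from compound 2 to compound 3 (0.14 log units; within the scatter). The estimated value for compound 3 is 7500 nM, with an expected range from 2500 nM to 20000 nM.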

Compound 3, half-maximal inhibitory concentration: 15600 nM
The estimate for compound 3 lay 2.1-fold (0.32 log units) below the measured number, within the range that was stated.
By their numbers in this assay, from the lowest: compounds 2, 3 and 1 (each within the scatter of the next, the first and the last beyond it).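

In this assay, hydroxy in place of hydrogen on this aromatic carbon gives a 1.5-fold higher number from compound 2 to compound 3 (0.18 log units; within the scatter), so compound 2 and compound 3 cannot be told apart. Among these compounds, this is the first direct reading of this single change, and at this position the added hydroxy neither clearly strengthens nor clearly weakens inhibition. Nothing available offers an explanation for this result.

From the compounds shown here alone, whether a different group on this same carbon, such as a methoxy group, an amine or a carboxylic acid, would move the number beyond the scatter remains open. Also open, going by these compounds, is whether hydroxy on another aromatic carbon of the shared core would behave the same way.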